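The source may report more compounds than this note shows. Statements on the series, on what has been measured and on what is new or still open speak of the compounds shown alone.

In an ADME assay on BJ cells (Homo sapiens) for antiproliferative activity, with a stated time of 72 h (a lower number here means that less compound is needed, a higher number that more compound is needed for the effect), compound 3 `COc1ccc(-c2cc(=O)c3c(OC)cc(OC)cc3n2S(=O)(=O)c2ccc(C#N)cc2)cc1` stands only at a limit of the assay: it gives > 17200 nM, a limit rather than a number. Its measured neighbours offer nothing firmer. Compound 2 `COc1ccc(-c2cc(=O)c3c(OC)cc(OC)cc3n2S(=O)(=O)c2ccc([N+](=O)[O-])cc2)cc1` gives > 29300 nM, again a limit. Compound 1 `COc1ccc(-c2c(I)c(=O)c3c(OC)cc(OC)cc3n2S(=O)(=O)c2ccc(OC)cc2)cc1` gives > 34400 nM, also a limit. Among the compounds with values here, the one step between measured compounds that differ in a single place, a step that the two limits leave unreadable from compound 2 to compound 3, cannot be sized because the limit of > 17200 nM in this assay, at which 1 of the 3 values shown sits, and the limit of > 29300 nM in this assay, at which 1 of the 3 values shown sits, are both limits.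

Compound 4 `COc1ccc(-c2cc(=O)c3c(OC)cc(OC)cc3n2S(=O)(=O)c2ccc(OC)cc2)cc1` differs from compound 3 by methoxy in place of cyano on an aromatic carbon. No measured step bears directly on this change, and the only step shown gives no readable size, so no direction beyond the scatter can be expected. Compound 1 already carries the same methoxy group that enters here and also sits at a limit, as the limit of > 34400 nM in this assay, at which 1 of the 3 values shown sits, records. Compound 4 is therefore expected to give about 30000 nM, with a range from 8000 nM to 100000 nM, most likely reported as a limit again. The step that the limit leaves unreadable from compound 3 to compound 4 is estimated to be essentially flat.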

Compound 4, half-maximal effective concentration: > 82700 nM
Compound 4: only a limit was reported; the forecaster's own chance of this, stated with the estimate: 80%; at least 2.7-fold (0.44 log units) between middle value and limit.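

Compound 4 gives only a limit, as do compound 1, compound 2 and compound 3, so none of the steps to compound 4 can be read in this assay. The compounds shown leave open whether swapping any of these groups changes the amount of compound needed for the effect.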